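Phenyl loss on the thiocarbonyl nitrogen of compound 2

The compounds below may be only part of what the source reports. "The series", "measured", "known", "first", "only" and "open" are said of these compounds alone.

Values in a functional assay on SW-620 cells (Homo sapiens) for antiproliferative activity, read by MTT assay, with a stated time of 72 h (a lower number here means a stronger inhibitor, a higher number a weaker inhibitor), follow
Compound 1 `NC(=S)N/N=C/c1ccccc1O` gives > 5000 nM as a limit of the assay
Compound 2 `COc1cccc(/C=N/NC(=S)Nc2ccccc2)c1O` gives 1600 nM
Compound 3 `Oc1ccccc1/C=N/NC(=S)Nc1ccccc1` gives 2000 nM

Compound 2 stands at 1600 nM and is level with compound 3 within the scatter. Compound 4 `COc1cccc(/C=N/NC(N)=S)c1O` departs from compound 2 by hydrogen in place of phenyl on an amide-type nitrogen. The nearest measured evidence is the reverse change, an at least 2.5-fold lower number from compound 1 to compound 3 (0.39 log units; beyond the scatter), phenyl in place of hydrogen on an amide-type nitrogen. Compound 1 reports only a limit, and the size of that step is therefore a bound. The other measured step, a 1.3-fold higher number from compound 2 to compound 3 (0.10 log units; within the scatter), hydrogen in place of methoxy on an aromatic carbon, lies within the scatter, so the phenyl step is expected to carry over to compound 2 with little alteration. A higher number is thus expected in this assay, and the reading may arrive only as a limit. The estimated step is a 4.4-fold higher number from compound 2 to compound 4 (0.64 log units; beyond the scatter) in this read-out. For compound 4 the estimated value is 7000 nM (expected range 3500 nM to 20000 nM).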

Compound 4, half-maximal inhibitory concentration: 500 nM
The estimate for compound 4 lay 14-fold (1.15 log units) above the measured number; the measured number lies below the stated range.
By their numbers in this assay, from the lowest: compound 4; then compounds 2 and 3 (each within the scatter of the next). At a limit, above all of these: compound 1.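

In this assay the phenyl on the amide-type nitrogen does not act alike on the two cores. With the methoxy present, its loss gives a 3.2-fold lower number from compound 2 to compound 4 (0.51 log units; beyond the scatter), the opposite direction to the step without the methoxy: the same change on two cores in this assay, an at least 2.5-fold lower number (0.39 log units; beyond the scatter) from compound 1 to compound 3 and a 3.2-fold higher number (0.51 log units; beyond the scatter) from compound 4 to compound 2, at least 8.0-fold (0.90 log units) apart, beyond the scatter of two such steps The methoxy in turn shows an effect only where hydrogen sits on that nitrogen, with an at least 10-fold lower number from compound 1 to compound 4 (1.00 log units; beyond the scatter), against a step within the scatter where phenyl sits there: the same change on two cores in this assay, a 1.3-fold higher number (0.10 log units; within the scatter) from compound 2 to compound 3 and an at least 10-fold higher number (1.00 log units; beyond the scatter) from compound 4 to compound 1, at least 8.0-fold (0.90 log units) apart, beyond the scatter of two such steps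

Compound 1 gives > 5000 nM, which is a limit of the assay, so both of its steps can be read only as bounds. The compounds shown leave open whether a methyl or an ethyl group on that nitrogen would stay with compound 4 or move toward compound 2, and whether an ethoxy group could stand in for the methoxy.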